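Aryl swap two bonds from the carbonyl: compound 3 to 4

The compounds below may be only part of what the source reports. "The series", "measured", "known", "first", "only" and "open" are said of these compounds alone.

Measured in an assay on HEK293 cells for displacement of a labelled ligand from Melanocortin receptor 4 (Homo sapiens); a higher number here means a weaker inhibitor, a lower number a stronger inhibitor:
compound 1 `CC(C)C[C@H](N)c1cc(C(F)(F)F)ccc1N1CCN(C(=O)C(C)Cc2ccc(Cl)c(Cl)c2)CC1` gives 120 nM; 1600 nM (2 entries).
compound 2 `CC(C)C[C@H](N)c1cc(C(F)(F)F)ccc1N1CCN(C(=O)CCC(=O)N(C)C)CC1` gives only a limit of the assay, > 10000 nM.
compound 3 `COc1ccc(CC(C)C(=O)N2CCN(c3ccc(C(F)(F)F)cc3[C@@H](N)CC(C)C)CC2)cc1F` gives 200 nM.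

Within the data shown here, compound 3 holds the only single number in this assay; one further entry is a limit and one further entry carries two values. Among the measured compounds shown here, the single step with both ends measured, an at least 50-fold lower number from compound 2 to compound 3 (1.69 log units; beyond the scatter), puts 1-(3-fluoro-4-methoxybenzyl)ethyl where 2-(dimethylcarbamoyl)ethyl stood on the carbonyl carbon, a large step. Compound 4 `Cc1ccc(CC(C)C(=O)N2CCN(c3ccc(C(F)(F)F)cc3[C@@H](N)CC(C)C)CC2)cc1C` differs from compound 3 by 3,4-dimethylphenyl in place of 3-fluoro-4-methoxyphenyl on a saturated chain carbon, two bonds along the chain from a carbonyl carbon. For the measured compounds named here, no measured step covers such a change; compound 1 shows 120 nM; 1600 nM (2 entries), and compound 3 shows 200 nM. The step of a 1.3-fold higher number from compound 3 to compound 4 (0.10 log units; within the scatter) is therefore expected to stay small, in no clear direction. Compound 4 is estimated at 250 nM, ranging from 80 nM to 800 nM.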

Compound 4, inhibition constant: 240 nM
Compound 4: middle estimate off by 1.0-fold (0.02 log units), on the high side; measured number inside the range.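

In this assay, the change at this saturated chain carbon gives a 1.2-fold higher number from compound 3 to compound 4 (0.08 log units; within the scatter), so an aryl group with no oxygen, fluorine or hydrogen-bond acceptor holds the number as well as 3-fluoro-4-methoxyphenyl does. The large step seen with compound 3 recurs with a second aryl group: an at least 41-fold lower number from compound 2 to compound 4 (1.61 log units; beyond the scatter). Compound 2 stands at a limit of the assay, not a number: the limit of > 10000 nM in this assay, at which 1 of the 4 values shown sits.

Where compound 1 falls against compound 3 and compound 4 stays unsettled: the several entries of compound 1 in this assay, 120 nM; 1600 nM (2 entries) Whether an amine or a carboxylic acid on the aromatic ring, or a longer chain leading to it, would keep this number also remains open.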